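A few compounds are considered here, and "the series" means these few. Any claim that something is new, unique, unknown or untested is made for them only; others in the source may bear on it.

Measured in an ADME assay on L1210/0 cells (Mus musculus) for cytotoxicity, with a stated time of 48 h; a higher number here means a weaker inhibitor, a lower number a stronger inhibitor:
- compound 1 `O=c1[nH]c(=O)n([C@H]2C[C@H](O)[C@@H](CO)O2)cc1/C=N/O`: 15500 nM
- compound 2 `O=c1[nH]c(=O)n([C@H]2C[C@H](O)[C@@H](CO)O2)cc1CO`: 9180 nM
- compound 3 `O=c1[nH]c(=O)n([C@H]2C[C@H](O)[C@@H](CO)O2)cc1[N+](=O)[O-]`: 130 nM

Compound 3 has the lowest number of the three, which makes it the strongest inhibitor here, and its steps to both others lie beyond the scatter. Compound 1 and compound 2 do not separate, with a 1.7-fold lower number from compound 1 to compound 2 (0.23 log units; within the scatter).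

The unmeasured compound 4 `C=Cc1cn([C@H]2C[C@H](O)[C@@H](CO)O2)c(=O)[nH]c1=O` keeps the core of compound 3 but carries vinyl in place of nitro on an aromatic carbon. Among the measured compounds shown here, two measured steps bear on this change, since each swaps another group for nitro on that carbon: a 120-fold lower number from compound 1 to compound 3 (2.08 log units; beyond the scatter) and a 71-fold lower number from compound 2 to compound 3 (1.85 log units; beyond the scatter). Both are large. Read backwards, they show that each of the two compounds without nitro has a far higher number than compound 3. Neither of them carries vinyl, so the data give only a rough guide to its effect. A clear rise in this assay is therefore expected on leaving nitro, possibly somewhat smaller than those two steps. The expected change is a 23-fold higher number from compound 3 to compound 4 (1.36 log units; beyond the scatter). For compound 4 the estimated value is 3000 nM, with an expected range from 600 nM to 15000 nM.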

Compound 4, half-maximal inhibitory concentration: 14200 nM
For compound 4 the middle estimate is 4.7-fold (0.68 log units) below the measured one; low and high end bracket the measured number.
By their numbers in this assay, from the lowest: compound 3; then compounds 2, 4 and 1 (each within the scatter of the next).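

In this assay, the change from nitro to vinyl gives a 110-fold higher number from compound 3 to compound 4 (2.04 log units; beyond the scatter), so a third group at this position now fails to reach the low number of compound 3, and this one contains only carbon. Vinyl also does not separate from the other two groups, with a 1.5-fold higher number from compound 2 to compound 4 (0.19 log units; within the scatter) and a 1.1-fold lower number from compound 1 to compound 4 (0.04 log units; within the scatter), so three different groups, with and without oxygen or nitrogen, fall together and among these four compounds only nitro stands apart. Nothing measured here accounts for the special place of nitro.

The compounds shown leave open whether nitro is truly unusual at this position or is simply the only one tried so far of a wider set of groups that could give a low number, such as a nitrile, a carboxylic acid, an amine, a halogen like fluorine or a longer chain like propyl. They also leave open whether the gap between nitro and vinyl would appear in the same way in any cell type other than the one used here.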